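Compound 4: a new group on the sulfonyl sulfur

The compounds below may be only part of what the source reports. "The series", "measured", "known", "first", "only" and "open" are said of these compounds alone.

Measured compounds:
Compound 1 `CCn1cc(C(=O)O)c(=O)c2cc(F)c(N3CCN(C(=N)NS(=O)(=O)c4cccc(Cl)c4)CC3)cc21`: 32 nM
Compound 2 `N=C(NS(=O)(=O)c1cccc(Cl)c1)N1CCN(c2cc3c(cc2F)c(=O)c(C(=O)O)cn3C2CC2)CC1`: 32 nM
Compound 3 `N=C(NS(=O)(=O)c1ccc(Cl)cc1)N1CCN(c2cc3c(cc2F)c(=O)c(C(=O)O)cn3C2CC2)CC1`: 32 nM

In a functional assay on HeLa cells (Homo sapiens) for antiproliferative activity, read by MTT assay, with a stated time of 72 h (on this read-out lower numbers stand for stronger inhibition and higher numbers for weaker inhibition), compound 1 gives 32 nM, level with compound 2 and compound 3 at the digits reported. The compound now awaiting measurement, compound 4 `CCn1cc(C(=O)O)c(=O)c2cc(F)c(N3CCN(C(=N)NS(=O)(=O)c4ccccc4C(F)(F)F)CC3)cc21`, keeps the ethyl group and the shared core of compound 1 and differs only in the group on the sulfonyl sulfur: 2-(trifluoromethyl)phenyl in place of 3-chlorophenyl on a sulfonyl sulfur.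

Two measured steps are available. The closer one, no change at the digits printed from compound 2 to compound 3 (within the scatter), also exchanges the group on a sulfonyl sulfur, with 4-chlorophenyl in place of 3-chlorophenyl, and stays within the scatter. The other, no change at the digits printed from compound 1 to compound 2 (within the scatter), puts cyclopropyl in place of ethyl on an aromatic nitrogen, is also within the scatter, and bears only loosely on the present change.

Among the measured compounds shown here, no measured compound carries 2-(trifluoromethyl)phenyl, so the evidence for this group is indirect and the range must stay wide. In this assay no step beyond the scatter is expected, in either direction. The estimate amounts to a 1.1-fold higher number from compound 1 to compound 4 (0.04 log units; within the scatter), an expected step of no real size. For compound 4 the expected value is 35 nM. The estimated range for compound 4 runs from 12 nM to 100 nM.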

Compound 4, half-maximal inhibitory concentration: 32 nM
The estimate for compound 4 lay 1.1-fold (0.04 log units) above the measured number; low and high end bracket the measured number.
By their numbers in this assay, from the lowest: compounds 1, 2, 3 and 4 (each within the scatter of the next).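

In this assay, replacing 3-chlorophenyl with 2-(trifluoromethyl)phenyl on the sulfonyl sulfur gives no change at the digits printed from compound 1 to compound 4 (within the scatter). The earlier step at this position only exchanged 3-chlorophenyl for 4-chlorophenyl, so the result extends the flat picture to an aryl group that has no chlorine and carries trifluoromethyl, with the heavy-atom count rising, and it does so with the ethyl group rather than the cyclopropyl group on the aromatic nitrogen. No measurement shown here explains why these exchanges leave the number level, and none bears on the properties of either group.

From the compounds shown here alone, the four compounds all keep an aryl group on the sulfonyl sulfur, so it remains open whether unsubstituted phenyl, a methyl group, a longer alkyl chain or an aminophenyl group would hold the same level, and whether 2-(trifluoromethyl)phenyl would do so alongside the cyclopropyl group. The carboxylic acid of the shared core is also constant throughout, which leaves open what an amide or an ester at that place would do in this assay.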